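This account rests on a few compounds, and the source may have more. Where it says the series, first, only, none or still open, it means among the compounds named here.

Measured in an assay on membranes from HeLa cells for displacement of a labelled ligand from adenosine receptor A3 (Homo sapiens), read by scintillation counting, with a stated time of 180 min, tested at 1 uM; a higher number here means more inhibition at the concentration tested (going by the name of the read-out), a lower number less inhibition:
Compound 1 `CCCOC(=O)C1=C(C)NC(=S)NC1c1ccoc1`: 3%
Compound 2 `CC1=C(C(=O)OCC(C)C)C(c2ccoc2)NC(=S)N1`: 1%
Compound 3 `CCNC(=O)C1=C(C)NC(=O)NC1c1ccoc1`: 1%

Compound 1 and compound 2 differ by one change, (methyl in place of hydrogen on a saturated chain carbon bound to two saturated chain carbons), and that change made the step of a number 2 percentage points lower from compound 1 to compound 2 (within the scatter). Compound 4 `CC1=C(C(=O)NC(C)C)C(c2ccoc2)NC(=O)N1` is reached from compound 3 by the same kind of change, (methyl in place of hydrogen on a saturated chain carbon bound to an amide-type nitrogen and a saturated chain carbon); the place differs in its surroundings, since the carbon in compound 4 is bound to an amide-type nitrogen and a saturated chain carbon rather than to two saturated chain carbons. How the core of compound 3 differs from the core of compound 1 is not broken down here. Compound 3 gives a value that is level with compound 2 in this assay . Because the earlier step of a number 2 percentage points lower from compound 1 to compound 2 (within the scatter) stayed within the scatter, the expected step is also small, no change at the digits printed from compound 3 to compound 4 (within the scatter). Compound 4 is therefore estimated at 1%, between -5% and 8%.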

Compound 4, a percentage reported as inhibition, at one concentration (the size of the read-out at that concentration, not a potency): 3%
Compound 4: middle estimate off by 2 percentage points, on the low side; the measured number falls inside the stated range.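

In this assay, the methyl that turns ethylcarbamoyl into isopropylcarbamoyl gives a number 2 percentage points higher from compound 3 to compound 4 (within the scatter). Set beside the earlier step, the same change reads alike on the two cores: the same change on two cores in this assay, a number 2 percentage points lower (within the scatter) from compound 1 to compound 2 and a number 2 percentage points higher (within the scatter) from compound 3 to compound 4, 4 percentage points apart, within the scatter of two such steps. This shows only that the added methyl made no readable difference on either core; it does not show that the change would carry over in general, as neither step is large enough to follow from one core to another.

The compounds shown leave open whether a longer chain, such as butyl, would give a number clear of the scatter. Going by these compounds, an amine at the end of that chain remains equally open.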